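This account rests on a few compounds, and the source may have more. Where it says the series, first, only, none or still open, it means among the compounds named here.

Measured in a functional assay on K562 cells (Homo sapiens) for inhibition, read by trypan blue exclusion, with a stated time of 72 h; on this read-out higher numbers stand for weaker inhibition and lower numbers for stronger inhibition:
- Compound 1 `Cn1c(=O)c(S(=O)(=O)c2ccc(F)cc2)cc2cnc(Nc3ccc4occc4c3)nc21`: 5000 nM
- Compound 2 `COc1ccc(Nc2ncc3cc(S(=O)(=O)c4ccc(C)cc4)c(=O)n(C)c3n2)cc1`: 75000 nM
- Compound 3 `COc1ccc(Nc2ncc3cc(S(=O)(=O)c4ccc(Cl)cc4)c(=O)n(C)c3n2)cc1`: 15000 nM

Of these three, compound 3 holds the middle number, lower than compound 2 and higher than compound 1. Compound 4 `Cn1c(=O)c(S(=O)(=O)c2ccc(Cl)cc2)cc2cnc(Nc3cnc4ccccc4c3)nc21` differs from compound 3 by quinolin-3-yl in place of 4-methoxyphenyl on a nitrogen on an aromatic ring. Going by the values given here, no measured step changes the group at that place. Among the compounds with values here, the only measured step, a 5.0-fold lower number from compound 2 to compound 3 (0.70 log units; beyond the scatter), is chloro in place of methyl on an aromatic carbon, so it serves only as a guide to size. That compound 1 gives 5000 nM, a lower number than compound 3, is a weak hint of direction. A modest step is therefore expected, a 2.1-fold lower number from compound 3 to compound 4 (0.33 log units; beyond the scatter), with wide uncertainty. For compound 4 the estimated value is 7000 nM, with an expected range of 1800 nM to 30000 nM.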

Compound 4, half-maximal inhibitory concentration: 15000 nM
Beside the measured number, compound 4's estimate is 2.1-fold (0.33 log units) below it; the measured number falls inside the stated range.
By their numbers in this assay, from the lowest: compound 1; then compounds 3 and 4 (each within the scatter of the next); then compound 2.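

In this assay, quinolin-3-yl in place of 4-methoxyphenyl on a nitrogen on an aromatic ring gives no change at the digits printed from compound 3 to compound 4 (within the scatter). Going by these compounds alone, this is the first measured step at this place, and it shows that adding a second aromatic ring, one with a ring nitrogen, leaves the number unmoved in this chloro series. No measurement shown here accounts for this result.

Only these two groups can be compared directly at this place. As far as these compounds go, whether a carboxylic acid or an amine on the aromatic group, or a morpholine ring in its place, would shift the number remains open.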